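The source may hold more compounds than are shown below. What is called first, only, known or untested is meant among the compounds shown, and "the series" means these compounds.

Compound 2, whose structure is `O=S(=O)(Nc1ccccc1)c1ccc2nc(-c3ccccc3)c(-c3ccccc3)nc2c1`, was tested in an ADME assay on the whole organism for pharmacokinetics, with Homo sapiens as the target; a lower number here means that a smaller share of the oral dose reaches the circulation, a higher number that a larger share of the oral dose reaches the circulation; compound 2 gives 100%. Its closest measured neighbour is compound 1, with structure `COc1ccccc1NS(=O)(=O)c1ccc2nc(-c3ccccc3)c(-c3ccccc3)nc2c1`, and in this assay compound 1 gives 100%. The step of no change at the digits printed from compound 1 to compound 2 (within the scatter) shows that replacing the methoxy on an aromatic carbon by hydrogen leaves the result unchanged within the scatter, so compound 2 stands level with compound 1.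

Compound 3, with structure `Cc1ccnc(NS(=O)(=O)c2ccc3nc(-c4ccccc4)c(-c4ccccc4)nc3c2)c1`, is not yet measured. It differs from compound 2 by 4-methylpyridin-2-yl in place of phenyl on a sulfonamide nitrogen, that is, 4-methylpyridin-2-yl in place of phenyl on the sulfonamide nitrogen. Among the measured compounds shown here, no measured step bears directly on this exchange; the only measured step, from compound 1 to compound 2, concerns a different position and was flat. Since both measured compounds sit at the top of the scale, compound 3 is expected to show a step of a number 10 percentage points lower from compound 2 to compound 3 (within the scatter) in this assay, at most a small decline. The estimate for compound 3 is 90%, with a range from 65% to 100%.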

Compound 3, oral bioavailability: 100%
For compound 3 the middle estimate is 10 percentage points below the measured one; low and high end bracket the measured number.
By their numbers in this assay, from the lowest: compounds 1, 2 and 3 (each within the scatter of the next).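

The exchange of phenyl for 4-methylpyridin-2-yl on the sulfonamide nitrogen gives, in this assay, no change at the digits printed from compound 2 to compound 3 (within the scatter); unlike the earlier step, this one replaces the whole group on that nitrogen, and a ring with a hetero atom takes the place of one of carbon only without a readable difference. Set against the methoxy-bearing group, 4-methylpyridin-2-yl in place of 2-methoxyphenyl gives no change at the digits printed from compound 1 to compound 3 (within the scatter). Nothing available accounts for this flat result at the position.

All three compounds stand level, so the compounds shown do not reveal which change on this nitrogen, if any, would lower the read-out. From the compounds shown here alone, whether a short alkyl chain, an amine or a carboxylic acid on the sulfonamide nitrogen would hold the value stays open, as does any change to the shared core.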